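From hydroxymethyl to butyl on the shared core

The source may report more compounds than this note shows. Statements on the series, on what has been measured and on what is new or still open speak of the compounds shown alone.

Values measured in a functional assay on IMR-32 cells (Homo sapiens) for antiproliferative activity, read by sulforhodamine B assay, with a stated time of 48 h (a higher number here means a weaker inhibitor of growth, a lower number a stronger inhibitor of growth), so far:
- compound 1 `O=C1COc2ccccc2N1CCCn1cc(-c2ccccn2)nn1` gives (2000 nM)
- compound 2 `O=C1COc2ccccc2N1CCCn1cc(CO)nn1` gives (5500 nM)

Of these two, compound 2 holds the highest number (5500 nM) in this assay and is the weaker inhibitor of growth. Compound 3 `CCCCc1cn(CCCN2C(=O)COc3ccccc32)nn1` differs from it as follows (propyl in place of hydroxy on a saturated chain carbon bound to an aromatic carbon), which reads as hydroxymethyl to butyl. Among the compounds with values here, one measured step bears on this, and it also concerns hydroxymethyl, a modest one (a 2.8-fold higher number from compound 1 to compound 2 (0.44 log units; beyond the scatter)). Within the data shown here, no measured compound carries butyl, so the ground is thin, but a modest step to a lower number is expected. For compound 3 the estimated value is 3000 nM, with an expected range from 1200 nM to 7500 nM as its limits. This estimate means an expected step (a 1.8-fold lower number from compound 2 to compound 3 (0.26 log units; within the scatter)).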

Compound 3, concentration for 50% growth inhibition: 5700 nM
Compound 3: middle estimate off by 1.9-fold (0.28 log units), on the low side; measured number inside the range.
By their numbers in this assay, from the lowest: compound 1; then compounds 2 and 3 (each within the scatter of the next).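

In this assay, the change from hydroxymethyl to butyl gives a 1.0-fold higher number from compound 2 to compound 3 (0.02 log units; within the scatter), so the two groups cannot be told apart at this position, even though hydroxy brings a hydrogen-bond donor and acceptor and propyl brings neither. Butyl in place of pyridin-2-yl gives a 2.9-fold higher number from compound 1 to compound 3 (0.45 log units; beyond the scatter), so compound 1 stays apart from both compounds with a saturated chain carbon at this place. No measurement at hand explains either step.

From the compounds shown here alone, whether an amine, a carboxylic acid or a chain longer than butyl would stay level with these two remains open. So does whether a phenyl ring would share the lower number of compound 1.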